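The source may report more compounds than this note shows. Statements on the series, on what has been measured and on what is new or still open speak of the compounds shown alone.

Among the compounds with values here, in a functional assay on the whole organism with Rattus norvegicus as the target (a lower number here means that less compound is needed, a higher number that more compound is needed for the effect), compound 1 `CCOCCOC(=O)C(=O)Nc1nc(-c2cc(OC)no2)cs1` gives 3 mg/kg as the lower of the two numbers so far, and compound 2 `CC(C)(C)OC(=O)C(=O)Nc1nc(-c2cc(-c3ccccc3)no2)cs1` gives 9 mg/kg with a gap beyond the usual scatter. The change ethoxycarbonyl in place of methoxy on an aromatic carbon puts ethoxycarbonyl in place of methoxy on an aromatic carbon in compound 3 `CCOCCOC(=O)C(=O)Nc1nc(-c2cc(C(=O)OCC)no2)cs1` while the core of compound 1 stays. Within the data shown here, no measured pair shows a change at this place. A modest rise in this assay is expected, perhaps none beyond the scatter. The estimated step of a 1.7-fold higher number from compound 1 to compound 3 (0.22 log units; within the scatter) stays small. For compound 3 the expected value is 5 mg/kg with an estimated range from 2 mg/kg to 14 mg/kg in the coming measurement.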

Compound 3, dose for half-maximal effect: 0.08 mg/kg
Beside the measured number, compound 3's estimate is 63-fold (1.80 log units) above it; the measured number lies below the stated range.
By their numbers in this assay, from the lowest: compound 3; then compound 1; then compound 2.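

In this assay the aromatic carbon next to the ring nitrogen proves a highly sensitive place: ethoxycarbonyl in place of methoxy gives a 38-fold lower number from compound 1 to compound 3 (1.57 log units; beyond the scatter) with the rest of the core of compound 1 unchanged. Compounds 1 and 2 differ in more than one place, so they could not show this. No available evidence accounts for the size of this step. On these data alone, whether it depends on the ester as a whole or on its ethyl part stays open, as does how a carboxylic acid, a primary amide or a longer ester chain would behave at this place.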